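Trimming the carbamate ester toward a simple isopropyl group

The source may hold more compounds than are shown below. What is called first, only, known or untested is meant among the compounds shown, and "the series" means these compounds.

Compound 2 `CC(OC(=O)C(C)C)OC(=O)N1CCN(C(=O)c2nc(Nc3cc(C4CC4)[nH]n3)c3cc(Cl)ccc3n2)C[C@H]1C` stands highest of the two compounds measured in an assay for inhibition of serine/threonine-protein kinase PAK 4 (Homo sapiens), read by FRET and Z'-LYTE, with a stated time of 60 min, tested at 5 uM, in the presence of a further agent that is not named here (a lower number here means a weaker effect, a higher number a stronger effect of the compound at the concentration tested), where compound 2 gives 25.8%. Compound 1 `CCCCCOC(=O)N1CCN(C(=O)c2nc(Nc3cc(C4CC4)[nH]n3)c3cc(Cl)ccc3n2)C[C@H]1C` differs from it only in the group carried on the oxygen of the carbamate, and in this assay compound 1 gives 12.6%. For the measured compounds named here, the single measured step in this set is a number 13.2 percentage points higher from compound 1 to compound 2 (beyond the scatter), a modest rise that lies beyond the usual scatter.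

Compound 3 `CC(C)OC(=O)N1CCN(C(=O)c2nc(Nc3cc(C4CC4)[nH]n3)c3cc(Cl)ccc3n2)C[C@H]1C` pares this position back further: methyl in place of (isopropylcarbonyl)oxy on a saturated chain carbon bound to an oxygen next to a carbonyl group and a saturated chain carbon. Going by the values given here, no measured pair reproduces this exact change. Among the compounds with values here, the only step available concerns the same oxygen of the carbamate and shows that the read-out in this assay is sensitive to what sits there by a modest margin. Because the group leaving compound 3 is the one whose arrival produced a number 13.2 percentage points higher from compound 1 to compound 2 (beyond the scatter), a decrease of comparable size appears the more likely direction, though a change within the scatter cannot be excluded. Compound 3 is therefore expected to give 15%, in a range from 3% to 30%. This estimate corresponds to an expected step of a number 10.8 percentage points lower from compound 2 to compound 3 (beyond the scatter).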

Compound 3, a percentage reported as inhibition, at one concentration (the size of the read-out at that concentration, not a potency): 75.8%
Beside the measured number, compound 3's estimate is 60.8 percentage points below it, outside the stated range (above it).
By their numbers in this assay, from the lowest: compound 1; then compound 2; then compound 3.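

Isopropyl on the oxygen next to a carbonyl group sets this position apart: the change from 1-((isopropylcarbonyl)oxy)ethyl gives a number 50 percentage points higher from compound 2 to compound 3 (beyond the scatter), and the change from pentyl gives a number 63.2 percentage points higher from compound 1 to compound 3 (beyond the scatter). For the compounds shown here, both steps are large, whereas the only step seen earlier, a number 13.2 percentage points higher from compound 1 to compound 2 (beyond the scatter), was modest and suggested that the read-out in this assay responded only moderately to what sits on this oxygen, so the position now appears far more sensitive, with the two larger groups both lying well under isopropyl. No measurement is available here that explains why isopropyl stands so far above the other two groups.

The compounds shown leave open whether this high read-out is particular to isopropyl or extends to neighbouring groups such as ethyl, tert-butyl or cyclopropyl, and whether the carbamate itself is needed, which a simple amide or a free amine at this place would test. All three numbers also come from a single concentration, so they describe the size of the effect at that concentration and leave the potency of compound 3 open.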